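Triazole hydroxamates: methyl to fluoro on the carbon-linked aryl

The source may report more compounds than this note shows. Statements on the series, on what has been measured and on what is new or still open speak of the compounds shown alone.

Measured so far in an assay on Sf9 cells for inhibition of protein deacetylase HDAC6 (Homo sapiens), read by fluorescence, with a stated time of 40 min; on this read-out lower numbers stand for stronger inhibition and higher numbers for weaker inhibition:
- compound 1 `Cc1ccc(-c2nc(CNc3ccc(C(=O)NO)cc3)n(-c3ccccc3)n2)cc1` gives 224 nM
- compound 2 `O=C(NO)c1ccc(NCc2nc(-c3ccccc3)nn2-c2ccc(Br)cc2)cc1` gives 1730 nM
- compound 3 `O=C(NO)c1ccc(NCc2nc(-c3ccccc3)nn2-c2cccc(Cl)c2)cc1` gives 678 nM

Compound 1 gives the lowest number of the three, beyond the scatter against both others. Going by the values given here, the only step between measured neighbours, a 2.6-fold lower number from compound 2 to compound 3 (0.41 log units; beyond the scatter), concerns the aryl on the triazole nitrogen, not the aryl on the triazole carbon.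

Compound 4 `O=C(NO)c1ccc(NCc2nc(-c3ccc(F)cc3)nn2-c2ccccc2)cc1` is not yet measured. It differs from compound 1 in one place: fluoro in place of methyl on an aromatic carbon, para to a large group, read one bond further out as 4-methylphenyl to 4-fluorophenyl. Among the compounds with values here, no measured step touches this aryl, so no measured step bears on the change; the expectation rests on the change being small in count and on compound 1 staying the reference point.

The number for compound 4 in this assay is expected to stay close to that of compound 1, a step of a 1.3-fold higher number from compound 1 to compound 4 (0.13 log units; within the scatter), not beyond the scatter in either direction. The estimate for compound 4 is 300 nM, with a range from 120 nM to 750 nM.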

Compound 4, half-maximal inhibitory concentration: 115 nM
Estimate against measurement, compound 4: 2.6-fold (0.42 log units) above; the measured number lies below the stated range.
By their numbers in this assay, from the lowest: compounds 4 and 1 (each within the scatter of the next); then compound 3; then compound 2.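

In this assay, going by these compounds alone, a 1.9-fold lower number from compound 1 to compound 4 (0.29 log units; within the scatter) is the only step read on this aryl, and the two compounds cannot be told apart. The position thus accepts 4-fluorophenyl in place of 4-methylphenyl with no difference the assay can resolve, which the earlier step, confined to the aryl on the ring nitrogen, could not show. Nothing measured here accounts for this outcome at the position.

Open, on these data alone, is whether an amine, a carboxylic acid or a methoxy group on this aromatic carbon would stay within the scatter of compound 1 or move beyond it. Also open, as far as these compounds go, is whether 4-fluorophenyl would keep the same relation to 4-methylphenyl with 3-chlorophenyl or 4-bromophenyl on the ring nitrogen.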